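Swapping Fluoro for Dimethylamino on the Pendant Phenyl

A few compounds are considered here, and "the series" means these few. Any claim that something is new, unique, unknown or untested is made for them only; others in the source may bear on it.

Compound 1 `COc1cc(-c2ccnc3cc(-c4ccc(F)cc4)nn23)cc(OC)c1OC` was tested in a functional assay on HCT-116 cells (Homo sapiens) for inhibition, read by CCK-8 assay, with a stated time of 48 h (on this read-out higher numbers stand for weaker inhibition and lower numbers for stronger inhibition), where compound 1 gives 5030 nM. Of the two numbers reported, that of compound 1 is the highest; the nearest is compound 2 `COc1cc(-c2ccnc3cc(-c4ccc(C)c(C)c4)nn23)cc(OC)c1OC`, which gives 261 nM, and the step of a 19-fold lower number from compound 1 to compound 2 (1.28 log units; beyond the scatter). Compound 3 `COc1cc(-c2ccnc3cc(-c4cccc(C#N)c4)nn23)cc(OC)c1OC` reaches only a limit in this assay, namely > 10000 nM. The two steps away from compound 2 read an at least 38-fold higher number from compound 2 to compound 3 (1.58 log units; beyond the scatter) and, from compound 1, an at least 1.9-fold higher number from compound 1 to compound 3 (0.29 log units; that floor lies within the scatter), so the ring that varies among these three compounds moves the number a great deal.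

Compound 4 `COc1cc(-c2ccnc3cc(-c4ccc(N(C)C)cc4)nn23)cc(OC)c1OC` differs from compound 1 by dimethylamino in place of fluoro on an aromatic carbon, that is 4-fluorophenyl to 4-(dimethylamino)phenyl. For the measured compounds named here, no measured step touches a dimethylamino group. Going by the values given here, the steps that bear on it are the two other changes at the same ring: a 19-fold lower number from compound 1 to compound 2 (1.28 log units; beyond the scatter) carried the number far down, whereas an at least 38-fold higher number from compound 2 to compound 3 (1.58 log units; beyond the scatter) carried it to the limit of > 10000 nM in this assay, at which 1 of the 3 values shown sits. A step beyond the scatter in this assay is therefore expected, though its direction is not fixed by these three compounds. Compound 4 is estimated at 1500 nM, within 300 nM to 8000 nM. That expectation corresponds to the step of a 3.4-fold lower number from compound 1 to compound 4 (0.53 log units; beyond the scatter).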

Compound 4, half-maximal inhibitory concentration: 2050 nM
The estimate for compound 4 lay 1.4-fold (0.14 log units) below the measured number; measured number inside the range.
By their numbers in this assay, from the lowest: compound 2; then compound 4; then compound 1. At a limit, above all of these: compound 3.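

In this assay, the exchange of fluoro for dimethylamino on an aromatic carbon, para to a large group, is the first change shown at this place that lowers the number only modestly, with a 2.5-fold lower number from compound 1 to compound 4 (0.39 log units; beyond the scatter) as its step. Compound 2 keeps the lower number, with a 7.9-fold higher number from compound 2 to compound 4 (0.90 log units; beyond the scatter) as the step, so 4-(dimethylamino)phenyl does not match 3,4-dimethylphenyl in this assay, although it still improves on 4-fluorophenyl. The step of an at least 4.8-fold lower number from compound 3 to compound 4 (0.68 log units; beyond the scatter) gives only a floor, since compound 3 stands at a limit of the assay: the limit of > 10000 nM in this assay, at which 1 of the 4 values shown sits.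

The compounds shown leave open whether a primary amine, a methylamino group or a morpholine ring in place of dimethylamino would give a number like that of compound 4, and whether a methoxy group there would do the same. They also leave open how dimethylamino would behave elsewhere on the ring, and whether a single methyl group at this place would move the number as far as the two methyl groups of compound 2 do.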